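Swapping the sulfonyl ring of a benzoxazole sulfonamide

A few compounds are considered here, and "the series" means these few. Any claim that something is new, unique, unknown or untested is made for them only; others in the source may bear on it.

The measured compounds:
compound 1, `O=S(=O)(Nc1ccc(-c2nc3ccccc3o2)cc1)c1cccs1`, 63000 nM in an assay on cells for inhibition of HSP60/HSP10 (Homo sapiens), with a stated time of 60 min; a lower number here means a stronger inhibitor, a higher number a weaker inhibitor
compound 2, `O=S(=O)(Nc1ccc2oc(-c3ccccc3)nc2c1)c1ccccc1Cl`, > 100000 nM
compound 3, `CS(=O)(=O)Nc1ccc2oc(-c3ccccc3)nc2c1`, > 100000 nM

Among the measured compounds shown here, compound 1 gives the only number here, 63000 nM. For compound 2 the assay reports only the limit > 100000 nM. For compound 3 the assay likewise reports only the limit > 100000 nM. Two of the three values therefore sit at the limit of > 100000 nM in this assay, at which 2 of the 3 values shown sit. For the measured compounds named here, the one step between measured compounds, a step that the two limits leave unreadable from compound 2 to compound 3, runs between two limits, so its size cannot be read.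

Compound 4, `O=S(=O)(Nc1ccc(-c2nc3ccccc3o2)cc1)c1ccc(Cl)cc1`, has not been measured. It differs from compound 1 in one place: 4-chlorophenyl in place of thiophen-2-yl on a sulfonyl sulfur. Going by the values given here, no measured step touches the sulfonyl ring of compound 1, so there is nothing to set a direction for this change. The expectation is therefore a step of a 1.1-fold lower number from compound 1 to compound 4 (0.02 log units; within the scatter), within the scatter. Compound 4 is estimated at 60000 nM, between 20000 nM and 150000 nM, with a fair chance that only a limit is reported.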

Compound 4, half-maximal inhibitory concentration: 61000 nM
Beside the measured number, compound 4's estimate is 1.0-fold (0.01 log units) below it; low and high end bracket the measured number.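

Putting 4-chlorophenyl in place of thiophen-2-yl on a sulfonyl sulfur gives a 1.0-fold lower number from compound 1 to compound 4 (0.01 log units; within the scatter) in this assay. Among the compounds shown here, this is the first step at this position that can be read, and it shows that the measurement does not separate these two aromatic rings, even though one has five members and a sulfur and the other has six members and a chlorine. Neither ring moves the core of compound 1 clear of the weak end of the range, close to where values are reported only as a limit: the limit of > 100000 nM in this assay, at which 2 of the 4 values shown sit.

From the compounds shown here alone, what a ring carrying a carboxylic acid or an amine, or a longer alkyl chain, would do on the sulfonyl sulfur stays open. So does whether any group there can bring the number down beyond the scatter.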